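Series notes: ring-opened ether side chain on compound 2

The compounds below may be only part of what the source reports. "The series", "measured", "known", "first", "only" and "open" are said of these compounds alone.

Compound 1 `O=C(/C=C/c1ccc(OCC2CO2)cc1)c1ccco1` gives 11300 nM in a functional assay on T47D cells (Homo sapiens) for inhibition, read by CCK-8 assay and cell counting, with a stated time of 2 days; a higher number here means a weaker inhibitor, a lower number a stronger inhibitor. Among the measured compounds shown here, compound 2 `O=C(/C=C/c1ccc(OCC2CO2)cc1)c1cccs1` gives 10600 nM in this assay; the single recorded step, a 1.1-fold lower number from compound 1 to compound 2 (0.03 log units; within the scatter), does not separate the two. Compound 2 therefore carries the lower of the two numbers, yet compound 1 lies within the scatter of it, so no ranking is justified.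

Compound 3 `O=C(/C=C/c1ccc(OCC(O)CCl)cc1)c1cccs1` differs from compound 2 at the ether side chain: 2-chloro-1-hydroxyethyl in place of oxiran-2-yl on a saturated chain carbon bound to an oxygen on an aromatic ring. For the measured compounds named here, no measured step touches this part of the molecule; the one step in hand, a 1.1-fold lower number from compound 1 to compound 2 (0.03 log units; within the scatter), concerns the group on the carbonyl carbon and left the number flat. The numbers thus give no basis for a directed expectation, and the step of a 1.1-fold higher number from compound 2 to compound 3 (0.05 log units; within the scatter) is expected to stay within the scatter, with a wide range allowed. Compound 3 is estimated at 12000 nM, between 4500 nM and 32000 nM.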

Compound 3, half-maximal inhibitory concentration: 13000 nM
The estimate for compound 3 lay 1.1-fold (0.03 log units) below the measured number; the measured number falls inside the stated range.
By their numbers in this assay, from the lowest: compounds 2, 1 and 3 (each within the scatter of the next).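

In this assay, among the compounds shown here, the first reading at the ether side chain is a 1.2-fold higher number from compound 2 to compound 3 (0.09 log units; within the scatter), with 2-chloro-1-hydroxyethyl in place of oxiran-2-yl on a saturated chain carbon bound to an oxygen on an aromatic ring. With thiophen-2-yl on the carbonyl carbon, the intact three-membered ring is therefore not required for a number of this size: the ring can give way to an open chain carrying chlorine and a hydrogen-bond donor, and the step stays within the scatter. No supporting data bear on why the number does not separate here.

From the compounds shown here alone, whether the same change reads alike with furan-2-yl on the carbonyl carbon remains open. Also open, going by these compounds, is whether an amine or a carboxylic acid in place of the chlorine, or a longer chain at this position, would give a step beyond the scatter.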